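A few compounds are considered here, and "the series" means these few. Any claim that something is new, unique, unknown or untested is made for them only; others in the source may bear on it.

In a functional assay on HCT-15 cells (Homo sapiens) for antiproliferative activity, read by MTT assay, with a stated time of 72 h (a higher number here means a weaker inhibitor, a lower number a stronger inhibitor), compound 1 `COc1cc(-c2nccn2C(C)C)cc(OC)c1OC` gives > 100000 nM, which is a limit of the assay and not a number. Compound 2 `COc1cc(-c2nccn2S(=O)(=O)c2ccccc2)cc(OC)c1OC` gives > 100000 nM, which is also a limit. Among the measured compounds shown here, compound 1 therefore has no numerical position, and no measured step is available to set the size of a change. Compound 3 `COc1cc(-c2nccn2-c2cccc(C)c2)cc(OC)c1OC` carries 3-methylphenyl in place of isopropyl on an aromatic nitrogen. In this assay the expected step is an at least 3.3-fold lower number from compound 1 to compound 3 (0.52 log units; beyond the scatter), a modest strengthening, although the assay may again report only a limit. For compound 3 the estimated value is 30000 nM, with an expected range of 3000 nM to 100000 nM.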

Compound 3, half-maximal inhibitory concentration: 1600 nM
The estimate for compound 3 lay 19-fold (1.27 log units) above the measured number; measured number outside the range, below it.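

In this assay, the aromatic nitrogen of the shared core turned out to be a place where a change can bring a measurable number: 3-methylphenyl in place of isopropyl gives an at least 62-fold lower number from compound 1 to compound 3 (1.79 log units; beyond the scatter) and so a large step. Among the compounds shown here, this is the first sign that the group on this nitrogen matters for activity in these cells. The step is read against a limit of the assay and not a number: the limit of > 100000 nM in this assay, at which 2 of the 3 values shown sit.

Whether the ring or its methyl carries the step stays open, as the compounds shown include no plain phenyl. They also do not tell how a methoxy or an amine on that ring would fare.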